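The compounds below may be only part of what the source reports. "The series", "measured", "known", "first", "only" and "open" are said of these compounds alone.

Measured compounds:
Compound 1, `CCCCNC(=O)c1c(O)c2cccnc2n(-c2ccccc2)c1=O`: 20.4%
Compound 2, `COc1ccc(NC(=O)c2c(O)c3cccnc3n(-c3ccccc3)c2=O)cc1`: -1.9%
Compound 3, `O=C(NCc1ccncc1)c1c(O)c2cccnc2n(-c2ccccc2)c1=O`: 15.4%

All three share one core and differ only in the group on the amide-type nitrogen. In a functional assay on the whole organism for inhibition, with Rattus norvegicus as the target, read by cytopathic effect and paw edema, at a dose of 100 mg/kg by the oral route (a higher number here means more inhibition at the dose given (going by the name of the read-out), a lower number less inhibition), compound 3 gives 15.4%, the second highest of the three numbers. Its nearest neighbour is compound 1, and that gap is within the scatter: a number 5 percentage points lower from compound 1 to compound 3 (within the scatter). The furthest is compound 2, which sits well below it: a number 17.3 percentage points higher from compound 2 to compound 3 (beyond the scatter).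

Compound 4, `O=C(Nc1ccc(Cl)nc1)c1c(O)c2cccnc2n(-c2ccccc2)c1=O`, is not yet measured. It differs from compound 3 in one place: 6-chloropyridin-3-yl in place of (pyridin-4-yl)methyl on an amide-type nitrogen. Among the measured compounds shown here, two measured steps bear on this. One is a number 22.3 percentage points lower from compound 1 to compound 2 (beyond the scatter), where a six-membered aromatic ring took the place of a chain on the amide-type nitrogen and the number fell beyond the scatter. The other is a number 17.3 percentage points higher from compound 2 to compound 3 (beyond the scatter), where that ring gave way to a (pyridin-4-yl)methyl and the number rose again. Compound 4 again carries a six-membered aromatic ring on the amide-type nitrogen, so a drop of modest size is expected, a number 12.4 percentage points lower from compound 3 to compound 4 (beyond the scatter). Compound 4 is therefore estimated to give 3%, with a range from -12% to 18%.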

Compound 4, a percentage reported as inhibition, in the whole organism at one dose (the size of the read-out at that dose, not a potency): -4%
The estimate for compound 4 lay 7 percentage points above the measured number, within the range that was stated.
By their numbers in this assay, from the lowest: compounds 4 and 2 (each within the scatter of the next); then compounds 3 and 1 (each within the scatter of the next).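

The two groups exchanged here match in every count, with the same number of heavy atoms and one six-membered aromatic ring with 1 hetero atom each, yet in this assay the change reads a number 19.4 percentage points lower from compound 3 to compound 4 (beyond the scatter), so those counts alone do not settle the number at this amide-type nitrogen. What separates them is that the ring of compound 4 sits directly on the nitrogen, as in compound 2, and these two compounds stand level despite their different rings, with 4-methoxyphenyl and 6-chloropyridin-3-yl giving a number 2.1 percentage points lower from compound 2 to compound 4 (within the scatter). Set against the butyl group, the change reads a number 24.4 percentage points lower from compound 1 to compound 4 (beyond the scatter), and none of the four compounds goes against the reading that a ring bound straight to this nitrogen goes with the low numbers.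

Nothing measured here offers a cause for this split. Still open, going by these compounds, is whether a plain phenyl, a benzyl or a chain longer than butyl on this nitrogen would follow the same split, and whether it would hold at other doses.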